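A few compounds are considered here, and "the series" means these few. Any claim that something is new, unique, unknown or untested is made for them only; others in the source may bear on it.

Measured compounds in an ADME assay on HEK293 cells (Homo sapiens) for cytotoxicity, read by resazurin assay, with a stated time of 48 h; a higher number here means that more compound is tolerated, a lower number that less compound is tolerated:
- compound 1 `O=S(=O)(Nc1ccc(-c2nc3ccccc3o2)cc1)c1cccc(Cl)c1`: > 100000 nM, a limit of the assay
- compound 2 `O=S(=O)(Nc1ccc(-c2nc3ccccc3o2)cc1)c1ccc(C(F)(F)F)cc1`: 94000 nM
- compound 3 `O=S(=O)(Nc1ccc(-c2nc3ccccc3o2)cc1)c1ccccc1Cl`: > 100000 nM, a limit of the assay

Compound 3 sits at the limit in this assay; its value > 100000 nM is a limit and not a number. The same holds for compound 1, whose value > 100000 nM is also a limit. Only compound 2 gives a number, 94000 nM. Within the data shown here, because of the limit of > 100000 nM in this assay, at which 2 of the 3 values shown sit, the one step between measured compounds, a step that the two limits leave unreadable from compound 1 to compound 3, cannot be read in either direction or size.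

The next compound is compound 4 `O=S(=O)(Nc1ccc(-c2nc3ccccc3o2)cc1)c1ccc(F)cc1`. The change from compound 3 is 4-fluorophenyl in place of 2-chlorophenyl on a sulfonyl sulfur. No measured step concerns a 4-fluorophenyl on the sulfonyl sulfur, and the only measured step of the set is unreadable, so nothing shown supports a shift in this assay one way or the other. Compound 4 is therefore expected to give about 100000 nM, with a range from 50000 nM to 250000 nM. The step of a number no higher from compound 3 to compound 4 (the limit leaves the size open) is expected to stay within the scatter, and a limit rather than a number is the likelier report for compound 4.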

Compound 4, half-maximal cytotoxic concentration: > 100000 nM
Compound 4 was reported as a limit (the forecaster's own chance of this, stated with the estimate: 60%); the middle value lies on the limit itself.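

In this assay compound 4, with a 4-fluorophenyl on the sulfonyl sulfur, gives > 100000 nM, a limit of the assay and not a number. Among these compounds, the fluoro in place of trifluoromethyl on an aromatic carbon gives the first readable step, an at least 1.0-fold higher number from compound 2 to compound 4 (0.02 log units; that floor lies within the scatter), so this change has only a floor, and its full size stays unknown. The steps from compound 1 and from compound 3 to compound 4 cannot be read, because both ends of each step sit at the same limit: the limit of > 100000 nM in this assay, at which 3 of the 4 values shown sit.

From the compounds shown here alone, of the four compounds, only compound 2 gives a number, so it remains open how far any group on the sulfonyl sulfur moves the tolerated concentration. Also open, going by these compounds, is how an amine or a carboxylic acid in place of the fluoro on an aromatic carbon would read in this assay.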